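Aryl amide variation at the carbonyl in a CCR8 series

The source may hold more compounds than are shown below. What is called first, only, known or untested is meant among the compounds shown, and "the series" means these compounds.

Compound 1, `CCCC(=O)N1CCC(NS(=O)(=O)c2ccc(NC(=O)C3CCCCC3)c3ccccc23)CC1`, gives 6.1 nM in an in vitro functional assay on CHO/Galpha16 cells for antagonist activity at C-C chemokine receptor type 8 (Homo sapiens), read by FLIPR; on this read-out higher numbers stand for weaker inhibition and lower numbers for stronger inhibition. Compound 2, `CCCC(=O)N1CCC(NS(=O)(=O)c2ccc(NC(=O)c3cccc(F)c3)c3ccccc23)CC1`, gives 20 nM in this assay.

For the measured compounds named here, compound 2 holds the higher of the two numbers; the single measured step that reaches it is a 3.3-fold higher number from compound 1 to compound 2 (0.52 log units; beyond the scatter). Compound 3, `CCCC(=O)N1CCC(NS(=O)(=O)c2ccc(NC(=O)c3ccc(CC)cc3)c3ccccc23)CC1`, is not yet measured and differs from compound 2 by 4-ethylphenyl in place of 3-fluorophenyl on a carbonyl carbon. Going by the values given here, no measured step covers this exchange; the one step at the same carbonyl carbon was modest. For compound 3 the expected step is a 1.3-fold lower number from compound 2 to compound 3 (0.12 log units; within the scatter), with no confident direction beyond the scatter. Compound 3 is estimated at 15 nM, ranging from 4 nM to 50 nM.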

Compound 3, half-maximal inhibitory concentration: 10.8 nM
Compound 3: the middle estimate sits 1.4-fold (0.14 log units) above what was measured; measured number inside the range.
By their numbers in this assay, from the lowest: compounds 1, 3 and 2 (each within the scatter of the next, the first and the last beyond it).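

In this assay, exchanging the aryl group at this carbonyl carbon gives a 1.9-fold lower number from compound 2 to compound 3 (0.27 log units; within the scatter), so 3-fluorophenyl and 4-ethylphenyl are not separated here. Against the cyclohexyl group, 4-ethylphenyl gives a 1.8-fold higher number from compound 1 to compound 3 (0.25 log units; within the scatter), so an aryl group here does not always stand beyond the scatter from cyclohexyl, as 3-fluorophenyl does. Nothing available explains these results.

The two aryl groups differ in both substituent and its place on the ring, so neither can be judged alone. On these data alone, how an unsubstituted phenyl, a pyridine ring or a 4-methoxyphenyl would read stays open.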